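The source may report more compounds than this note shows. Statements on the series, on what has been measured and on what is new or still open speak of the compounds shown alone.

Series so far:
compound 1, `CN(C)CCn1cnnc1-c1cc(Oc2ccc(NC(=O)N/N=C/c3cccc(O)c3)cc2F)ccn1`, in a functional assay on A549 cells (Homo sapiens) for cytotoxicity, read by MTT assay, with a stated time of 72 h (a lower number here means a stronger inhibitor, a higher number a weaker inhibitor), gives > 100000 nM, which is a limit and not a number.
compound 2, `CN(C)CCn1cnnc1-c1cc(Oc2ccc(NC(=O)N/N=C/c3cc(Br)c(O)c(Br)c3)cc2F)ccn1`, gives > 100000 nM, likewise a limit.
compound 3, `CN(C)CCn1cnnc1-c1cc(Oc2ccc(NC(=O)N/N=C/c3ccc(F)cc3)cc2F)ccn1`, not yet measured.

Compound 2 therefore stands at the limit, one of the two values that sit there (the limit of > 100000 nM in this assay, at which 2 of the 2 values shown sit). Going by the values given here, the only step among the measured compounds, a step that the two limits leave unreadable from compound 1 to compound 2, runs between two limits and cannot be read for size or direction.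

The change to compound 3 is 4-fluorophenyl in place of 3,5-dibromo-4-hydroxyphenyl on a carbon with a double bond to nitrogen. Among the compounds with values here, no measured step bears on this change in a readable way: the one step recorded concerns the same carbon with a double bond to nitrogen, but it joins two limits and gives no scale for what exchanging this ring does. With nothing readable, the expectation in this assay is no step beyond the scatter, so compound 3 is expected to stay near the limit, with a number no higher from compound 2 to compound 3 (the limit leaves the size open) as the estimated step. The estimate for compound 3 is 100000 nM, range 30000 nM to 300000 nM, and a further limit rather than a number is the likeliest outcome.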

Compound 3, half-maximal inhibitory concentration: 1790 nM
Beside the measured number, compound 3's estimate is 56-fold (1.75 log units) above it; the measured number lies below the stated range.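

In this assay, the group on the carbon with a double bond to nitrogen proves able to move the read-out, which the earlier pair could not show: the 4-fluorophenyl ring gives an at least 55-fold lower number from compound 2 to compound 3 (1.74 log units; beyond the scatter) and an at least 55-fold lower number from compound 1 to compound 3 (1.74 log units; beyond the scatter). As far as these compounds go, the values of compound 1 and compound 2 are limits, so these steps fix only a minimum size and the full size stays open: the limit of > 100000 nM in this assay, at which 2 of the 3 values shown sit. Both rings at the limit, 3-hydroxyphenyl and 3,5-dibromo-4-hydroxyphenyl, carry a hydroxy group and the 4-fluorophenyl ring carries none, a pattern that rests on these three compounds alone, with none among them going against it.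

The compounds shown do not separate the arrival of the fluorine from the loss of the hydroxy group, and a plain phenyl, 4-chlorophenyl or 4-methoxyphenyl ring at this place would bear on that question. From the compounds shown here alone, the rest of the structure is the same in all three compounds, so it remains open whether the step holds once the dimethylaminoethyl chain is replaced by a morpholine-bearing chain or a simple methyl group.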